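The source may report more compounds than this note shows. Statements on the series, on what has been measured and on what is new or still open speak of the compounds shown alone.

In a series built on one shared core, the compounds were compared in a functional assay on SMMC-7721 cells (Homo sapiens) for inhibition, read by CCK-8 assay, with a stated time of 72 h, tested at 8 uM; a lower number here means less inhibition of growth, a higher number more inhibition of growth at the concentration tested. Compound 1 `Nc1ccccc1NC(=O)c1ccc(CSc2ccc(Br)cc2)cc1` gives 25.3% in this assay. Compound 2 `Nc1ccccc1NC(=O)/C=C/c1ccc(CSc2ccc(Cl)cc2)cc1` gives 16.5% in this assay. Of the two numbers recorded, that of compound 1 is the higher, yet the gap to compound 2 lies within the usual scatter of repeated measurements, so the two cannot be separated on these numbers.

Compound 3 `Nc1ccccc1NC(=O)c1ccc(CSc2ccc(F)cc2)cc1` has not yet been measured in this assay. Relative to compound 1 it shows one change: fluoro in place of bromo on an aromatic carbon. The exchange sits on a six-membered aromatic ring of carbon only, para to a large group, and nothing else in the molecule moves.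

Within the data shown here, no pair of measured compounds isolates this kind of exchange, so the size of the step in this assay rests on expectation alone. The step from bromo to fluoro is expected to be small, and a change of a number 3.3 percentage points lower from compound 1 to compound 3 (within the scatter) is estimated, that is, none beyond the scatter. Compound 3 is therefore expected to give about 22%, within a range of 10% to 34%.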

Compound 3, percent growth inhibition at one concentration: 81.9%
Compound 3: the middle estimate sits 59.9 percentage points below what was measured; measured number outside the range, above it.
By their numbers in this assay, from the lowest: compounds 2 and 1 (each within the scatter of the next); then compound 3.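

In this assay, fluoro in place of bromo on the aromatic carbon, para to a large group, gives a number 56.6 percentage points higher from compound 1 to compound 3 (beyond the scatter) and is a large step. It shows that this position of the shared core is sensitive to the identity of its substituent, as the exchange of one halogen for another is enough to set compound 3 apart from compound 1, while the ring, the net charge and the counted hydrogen-bond donors and acceptors stay the same. The earlier compounds could not show this, as no measured pair isolated a change at this place, and nothing available here bears on the reason for the step.

The compounds shown leave open whether the gain is particular to fluoro or would also appear with hydrogen, an amine, a methoxy group or a carboxylic acid on the same carbon. They also leave open whether the same exchange would carry over to the core of compound 2, which holds chloro at the corresponding place, and how the step would look across a range of concentrations rather than at a single one.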